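Aryl substituent swap: cyclohexyl replaced by sulfamoyl

The source may hold more compounds than are shown below. What is called first, only, known or untested is meant among the compounds shown, and "the series" means these compounds.

Measured values in a functional assay on L5178Y cells (Mus musculus) for inhibition; a lower number here means a less potent compound, a higher number a more potent compound, by a factor of ten per unit of this negative logarithm:
compound 1, `CCCCCCCCCCCCOc1cccc(N2C(N)=NC(N)=NC2(C)C)c1`, gives 6.41
compound 2, `CC1(C)N=C(N)N=C(N)N1c1cccc(C2CCCCC2)c1`, gives 7.97
compound 3, `CC1(C)N=C(N)N=C(N)N1c1cccc(OCCOc2ccccc2)c1`, gives 7.34

Compound 2 holds the highest number of the three. Compound 3 is nearest, lower by a gap beyond the scatter, and compound 1 is furthest, lower by a gap that is also beyond the scatter. For the measured compounds named here, all three share the same core and differ only in the group attached to the aryl ring, yet no pair differs in a single place, so there is no directly comparable step to lean on.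

Compound 4, `CC1(C)N=C(N)N=C(N)N1c1cccc(S(N)(=O)=O)c1`, is the next compound for this assay. Relative to compound 2 the change is sulfamoyl in place of cyclohexyl on an aromatic carbon. The group that leaves is a carbon ring with no donor or acceptor; the group that enters carries one donor and two acceptors.

Every measured compound carries a sizeable carbon-rich group at that position, and the numbers span a wide range without any anchored single-change step. The expectation for compound 4 is a fall, with the estimated step of a number 1.17 log units lower from compound 2 to compound 4 (beyond the scatter) taken as beyond the scatter. The estimated value for compound 4 is 6.8, with a range from 6 to 7.6.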

Compound 4, logarithm of the reciprocal of the active concentration, log(1/C): 5.61
Beside the measured number, compound 4's estimate is 1.19 log units above it; the measured number lies below the stated range.
By their numbers in this assay, from the lowest: compound 4; then compound 1; then compound 3; then compound 2.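

In this assay, for the compounds shown here, the exchange of cyclohexyl for sulfamoyl on an aromatic carbon gives the first single-change step at this position, a number 2.36 log units lower from compound 2 to compound 4 (beyond the scatter), and that step is large. The earlier compounds shown here showed only a spread of numbers across groups that differ from one another in more than one feature, whereas this pair shows that the position does not tolerate every group equally: the number drops sharply when a six-membered carbon ring with no hydrogen-bond donors or acceptors gives way to an open group that carries both. The exchange alters ring, heavy-atom count, donors and acceptors together, and nothing measured here bears on which of these lies behind the fall.

The compounds shown leave open whether the fall follows the loss of the carbon ring or the entry of the sulfamoyl group itself. A methylsulfonyl group, or a small open carbon group such as isopropyl, would help separate these two readings at the same aromatic carbon.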